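Thiophen-3-yl for benzofuran-2-yl on two ribosylated cores

The compounds below may be only part of what the source reports. "The series", "measured", "known", "first", "only" and "open" are said of these compounds alone.

Four compounds share a ribosylated bicyclic core and differ at the aryl group on the five-membered ring and in the core itself. Compound 1 `Cc1ncnc2c1c(-c1cc3ccccc3o1)cn2[C@@H]1O[C@H](CO)[C@@H](O)[C@H]1O` carries a 1-benzofuran-2-yl group; compound 3 `Cc1ncnc2c1c(-c1ccsc1)cn2[C@@H]1O[C@H](CO)[C@@H](O)[C@H]1O` carries thiophen-3-yl on the same core. Compound 2 `Cc1nc(N)c2c(-c3cc4ccccc4o3)cn([C@@H]3O[C@H](CO)[C@@H](O)[C@H]3O)c2n1` bears the benzofuran on a second core, and the unmeasured compound 4 `Cc1nc(N)c2c(-c3ccsc3)cn([C@@H]3O[C@H](CO)[C@@H](O)[C@H]3O)c2n1` is its thiophene counterpart. The difference between the two cores is not broken down here.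

In a functional assay on HCT-116 cells (Homo sapiens), read by MTT assay, with a stated time of 72 h (on this read-out higher numbers stand for weaker inhibition and lower numbers for stronger inhibition), compound 1 gives only a limit, > 20000 nM. Compound 3 gives 1430 nM, so the change thiophen-3-yl in place of 1-benzofuran-2-yl on an aromatic carbon produces an at least 13-fold lower number from compound 1 to compound 3 (1.14 log units; beyond the scatter). The size of that step rests on the limit of > 20000 nM in this assay, at which 1 of the 3 values shown sits, at which compound 1 sits, so its true size is only known to be at least this large.

Compound 2 gives 13100 nM in this assay, the highest of the two numbers measured; compound 3 lies well below it.

Going by the values given here, the change from compound 2 to compound 4, (thiophen-3-yl in place of 1-benzofuran-2-yl on an aromatic carbon), is the same change, on the same place, as the one from compound 1 to compound 3. A step of similar direction and size is expected: a 15-fold lower number from compound 2 to compound 4 (1.16 log units; beyond the scatter), resting on the step of an at least 13-fold lower number from compound 1 to compound 3 (1.14 log units; beyond the scatter) and on the value of compound 2, 13100 nM. Compound 4 is therefore estimated at 900 nM, with a range from 250 nM to 3500 nM.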

Compound 4, half-maximal inhibitory concentration: > 20000 nM
Compound 4: a limit, no number (the forecaster's own chance of this, stated with the estimate: 3%); middle value at least 22-fold (1.34 log units) away from the limit.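

Compound 4 gives only a limit in this assay, > 20000 nM. Thiophen-3-yl in place of 1-benzofuran-2-yl therefore does not carry over from one core to the other, as the outcome of this change in this assay depends on the core, with an at least 1.5-fold higher number from compound 2 to compound 4 (0.18 log units; that floor lies within the scatter) on the second core and the gain seen on the core of compound 1 absent there: the same change on two cores in this assay, an at least 13-fold lower number (1.14 log units; beyond the scatter) from compound 1 to compound 3 and an at least 1.5-fold higher number (0.18 log units; that floor lies within the scatter) from compound 2 to compound 4, at least 21-fold (1.32 log units) apart, beyond the scatter of two such steps

This does not show that the change truly weakens inhibition on the second core, since the floor of that step lies within the scatter, and the true size of neither step is known, as each rests on the same limit of the assay: the limit of > 20000 nM in this assay, at which 2 of the 4 values shown sit.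

Going by these compounds alone, the series holds only one pair of aryl groups on two cores, so it remains open whether the dependence on the core is general or particular to this pair, and no reason for it can be drawn from these compounds. A phenyl or thiophen-2-yl group on the same aromatic carbon of both cores would show whether other replacements for 1-benzofuran-2-yl carry from one core to the other.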